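Methyl added ortho to the ring hydroxy of compound 1

The source may report more compounds than this note shows. Statements on the series, on what has been measured and on what is new or still open speak of the compounds shown alone.

Measured compounds:
- compound 1 `CCCc1cc(O)cc(=O)n1Cc1ccc(-c2ccccc2-c2nn[nH]n2)cc1`, 0.048 mg/kg
- compound 2 `CCCc1cc(CO)cc(=O)n1Cc1ccc(-c2ccccc2-c2nn[nH]n2)cc1`, 0.3 mg/kg
- compound 3 `CCCc1cc(OCc2cccnc2)cc(=O)n1Cc1ccc(-c2ccccc2-c2nn[nH]n2)cc1`, 0.72 mg/kg

In a functional assay on the whole organism with Rattus norvegicus as the target (on this read-out higher numbers stand for an effect only at larger amounts of compound and lower numbers for an effect already at smaller amounts), compound 1 gives the lowest number of the three, and both of its steps to the others lie beyond the scatter: a 6.3-fold higher number from compound 1 to compound 2 (0.80 log units; beyond the scatter) and a 15-fold higher number from compound 1 to compound 3 (1.18 log units; beyond the scatter). Between the other two, a 2.4-fold higher number from compound 2 to compound 3 (0.38 log units; beyond the scatter). Both measured changes touch the hydroxy of compound 1, either converting it or capping it, and both weaken the effect.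

Compound 4 `CCCc1cc(O)c(C)c(=O)n1Cc1ccc(-c2ccccc2-c2nn[nH]n2)cc1` differs from compound 1 by methyl in place of hydrogen on an aromatic carbon. Going by the values given here, no measured step adds a group while keeping the hydroxy intact, so the two steps from compound 1 bear on this only indirectly: they show that the hydroxy region of the core is sensitive, with the modest loss a 6.3-fold higher number from compound 1 to compound 2 (0.80 log units; beyond the scatter) and the large loss a 15-fold higher number from compound 1 to compound 3 (1.18 log units; beyond the scatter) when it is altered. A methyl leaves the hydroxy in place, so a smaller shift is expected, in this assay most likely toward a higher number but possibly within the scatter.

Compound 4 is expected to give 0.1 mg/kg, in the range 0.03 mg/kg to 0.4 mg/kg, meaning an estimated step of a 2.1-fold higher number from compound 1 to compound 4 (0.32 log units; beyond the scatter).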

Compound 4, dose for 50% inhibition: 0.027 mg/kg
Compound 4: middle estimate off by 3.7-fold (0.57 log units), on the high side; the whole stated range lies above it.
By their numbers in this assay, from the lowest: compounds 4 and 1 (each within the scatter of the next); then compound 2; then compound 3.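

In this assay a methyl on this aromatic carbon, ortho to a hydroxy group, is accepted: the step is a 1.8-fold lower number from compound 1 to compound 4 (0.25 log units; within the scatter), so compound 1 and compound 4 cannot be told apart on this read-out. Compound 2 and compound 3 showed only that replacing or capping the hydroxy raises the number; compound 4 adds that, with the hydroxy kept, this neighbouring carbon takes a methyl without a step beyond the scatter. No measured data explain this result.

Going by these compounds, whether the position accepts an ethyl, a longer chain, a chlorine atom, an amine or a carboxylic acid remains open. Also open, on these data alone, is whether the methyl would alter the steps seen with hydroxymethyl or (pyridin-3-yl)methoxy in place of the hydroxy.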